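Swapping Chloro for Fluoro on the Aryl Ether Ring

The source may report more compounds than this note shows. Statements on the series, on what has been measured and on what is new or still open speak of the compounds shown alone.

Going by the values given here, compound 2 `Cc1cc2c(c(Oc3cc(NS(=O)(=O)c4ccc(Cl)cc4)ccc3Cl)n1)C(=O)N(C(C)C)C2=O` gives 33 nM in a functional assay on HEK293 cells for agonist activity at Glucose-dependent insulinotropic receptor (Homo sapiens), read by cAMP accumulation, with a stated time of 30 min (a higher number here means that more compound is needed for the effect, a lower number that less compound is needed), the higher of the two numbers measured so far; its only neighbour is compound 1 `Cc1cc2c(c(Oc3cccc(NS(=O)(=O)c4ccc(Cl)cc4)c3)n1)C(=O)N(C(C)C)C2=O`, which in this assay gives 13 nM. Among the compounds with values here, the single measured step, a 2.5-fold higher number from compound 1 to compound 2 (0.40 log units; beyond the scatter), came from a chloro in place of hydrogen on an aromatic carbon. Compound 3 `Cc1cc2c(c(Oc3cc(NS(=O)(=O)c4ccc(Cl)cc4)ccc3F)n1)C(=O)N(C(C)C)C2=O` has not yet been measured; it differs from compound 2 by fluoro in place of chloro on an aromatic carbon. Within the data shown here, the earlier step bears on this one only loosely, since it added a halogen where the new change exchanges one halogen for another, and no measured pair shows such an exchange. Because a 2.5-fold higher number from compound 1 to compound 2 (0.40 log units; beyond the scatter) was modest, the move to the smaller halogen is expected to shift the number only slightly, if at all. Compound 3 is therefore estimated at 20 nM, within 8 nM to 50 nM, a step of a 1.7-fold lower number from compound 2 to compound 3 (0.22 log units; within the scatter) expected to stay within the scatter.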

Compound 3, half-maximal effective concentration: 16 nM
For compound 3 the middle estimate is 1.3-fold (0.10 log units) above the measured one; the range from low to high includes it.
By their numbers in this assay, from the lowest: compounds 1 and 3 (each within the scatter of the next); then compound 2.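

At this position, ortho to a large group and para to a ((4-chlorophenyl)sulfonyl)amino group, the choice of halogen makes a difference in this assay: fluoro in place of chloro gives a 2.1-fold lower number from compound 2 to compound 3 (0.31 log units; beyond the scatter) and so goes beyond the scatter. Fluoro in place of hydrogen, by contrast, gives a 1.2-fold higher number from compound 1 to compound 3 (0.09 log units; within the scatter) and stays within it, so among the three compounds only chloro separates from the others at this position. Nothing available here accounts for the difference between the two halogens.

From the compounds shown here alone, whether a methyl group, a methoxy group or a nitrile at this position would match hydrogen and fluoro or match chloro remains open. So does whether the same exchange of halogens would give a similar step with a group other than 4-chlorophenyl on the sulfonyl.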